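The source may report more compounds than this note shows. Statements on the series, on what has been measured and on what is new or still open speak of the compounds shown alone.

In a functional assay on DU-145 cells (Homo sapiens) for cytotoxicity, read by CCK-8 assay and cell counting, with a stated time of 2 days (on this read-out higher numbers stand for weaker inhibition and lower numbers for stronger inhibition), three compounds have so far been measured. Compound 1 `Oc1ccc(-c2cc(-c3ccsc3)nc(-c3cccc(Cl)c3)c2)cc1` gives 6220 nM. Compound 2 `Oc1ccc(-c2cc(-c3cccc(Cl)c3)nc(-c3ccco3)c2)cc1` gives 5750 nM. The change between them, (furan-2-yl in place of thiophen-3-yl on an aromatic carbon), made the step of a 1.1-fold lower number from compound 1 to compound 2 (0.03 log units; within the scatter). Compound 3 `Oc1cccc(-c2cc(-c3ccsc3)nc(-c3ccccc3Cl)c2)c1` gives 1970 nM, the lowest of the three numbers, and its gaps to compound 2 and to compound 1 both lie beyond the scatter. Compound 3 and compound 1 hold the same atoms joined differently; the difference between the two cores is not broken down here. Compound 4 `Oc1cccc(-c2cc(-c3ccco3)nc(-c3ccccc3Cl)c2)c1` has not yet been measured in this assay. It differs from compound 3 by furan-2-yl in place of thiophen-3-yl on an aromatic carbon. This is the same kind of change as that from compound 1 to compound 2, but not the same: in compound 3 the aromatic carbon is meta to a 2-chlorophenyl group and meta to a 3-hydroxyphenyl group, whereas in compound 1 it is meta to a 3-chlorophenyl group and meta to a 4-hydroxyphenyl group. Because the step of a 1.1-fold lower number from compound 1 to compound 2 (0.03 log units; within the scatter) stayed within the scatter, the step expected for compound 4 is a 1.1-fold lower number from compound 3 to compound 4 (0.04 log units; within the scatter). The estimate for compound 4 in this assay is 1800 nM, expected to fall between 800 nM and 4000 nM.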

Compound 4, half-maximal inhibitory concentration: 1630 nM
For compound 4 the middle estimate is 1.1-fold (0.04 log units) above the measured one; low and high end bracket the measured number.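

In this assay, furan-2-yl in place of thiophen-3-yl on the core of compound 3 gave a small step, a 1.2-fold lower number from compound 3 to compound 4 (0.08 log units; within the scatter). Set beside the earlier case, the step carried over from one core to the other without a measurable difference: the same change on two cores in this assay, a 1.1-fold lower number (0.03 log units; within the scatter) from compound 1 to compound 2 and a 1.2-fold lower number (0.08 log units; within the scatter) from compound 3 to compound 4, 1.1-fold (0.05 log units) apart, within the scatter of two such steps. Within the data shown here, this shows that, on these two cores and in this one cell assay, the two five-membered aromatic rings could stand in for each other, but it rests on only two pairs and does not show that the same would hold on any further core, or for any other ring in that place.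

The compounds shown leave open how the gap between the two cores divides between the chlorophenyl and the hydroxyphenyl groups. They also leave open what a saturated ring such as piperidine or a chain bearing an amine would do in place of the five-membered ring, and what a carboxylic acid would do in place of the hydroxyl group.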